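Removing the Carboxy Group: Expected Effect on Cell Toxicity

The source may hold more compounds than are shown below. What is called first, only, known or untested is meant among the compounds shown, and "the series" means these compounds.

Measured in an ADME assay on HEK293 cells (Homo sapiens) for cytotoxicity, read by CCK-8 assay, with a stated time of 48 h; on this read-out lower numbers stand for stronger inhibition and higher numbers for weaker inhibition:
- compound 1, `COc1ccc(/C=C\c2cc(OC)c(OC)c(OC)c2)cc1OCc1ccc(C=O)cc1`: 46000 nM
- compound 2, `COc1ccc(/C=C\c2cc(OC)c(OC)c(OC)c2)cc1OCc1ccc(CN2C[C@H](O)C[C@@H]2C(=O)O)cc1`: > 50000 nM, a limit of the assay
- compound 3, `COc1ccc(/C=C\c2cc(OC)c(OC)c(OC)c2)cc1OCc1ccc(CN2CCCC[C@H]2C(=O)O)cc1`: > 50000 nM, also a limit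

Compound 2 stands at the limit, so only a floor is known for it, and one further value shares that floor, (the limit of > 50000 nM in this assay, at which 2 of the 3 values shown sit). The steps of an at least 1.0-fold higher number from compound 1 to compound 2 (0.03 log units; that floor lies within the scatter) and an at least 1.0-fold higher number from compound 1 to compound 3 (0.03 log units; that floor lies within the scatter) are floors within the scatter, and a step that the two limits leave unreadable from compound 2 to compound 3 cannot be read. Compound 4, `COc1ccc(/C=C\c2cc(OC)c(OC)c(OC)c2)cc1OCc1ccc(CN2CC[C@@H](O)C2)cc1`, differs from compound 2 by hydrogen in place of carboxy on a saturated ring carbon. With every measured step flat or unreadable, no shift beyond the scatter is expected, a number no higher from compound 2 to compound 4 (the limit leaves the size open). Compound 4 is therefore estimated at 50000 nM, between 20000 nM and 100000 nM, most likely again a limit.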

Compound 4, half-maximal inhibitory concentration: > 50000 nM
Compound 4: a limit, no number; the forecaster's own chance of this, stated with the estimate: 60%; the middle value sits exactly at the limit.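

In this assay compound 4, which carries hydrogen instead of carboxy on the saturated ring carbon, gives > 50000 nM, again a limit. A carboxy group at this position is therefore not required for a compound to reach that limit, and the step of an at least 1.0-fold higher number from compound 1 to compound 4 (0.03 log units; that floor lies within the scatter) is only a floor within the scatter. The steps linking compound 2, compound 3 and compound 4 cannot be read, and the values share one ceiling of the read-out: the limit of > 50000 nM in this assay, at which 3 of the 4 values shown sit.

As far as these compounds go, the true values of these three compounds stay open. So does whether an amine or a methyl ester on this ring carbon would give a readable number.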